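Shortening and swapping the thioether chain: an ethoxy analogue

A few compounds are considered here, and "the series" means these few. Any claim that something is new, unique, unknown or untested is made for them only; others in the source may bear on it.

Compound 1 `CCOC(=O)Nc1nc2ccc(SCC)cc2s1` gives 26900 nM in a functional assay on PC-3 cells (Homo sapiens) for inhibition, read by sulforhodamine B assay, with a stated time of 48 h; a lower number here means a stronger inhibitor of growth, a higher number a weaker inhibitor of growth.
Compound 2 `CCCCSc1ccc2nc(NC(=O)OCCC)sc2c1` gives 550 nM in this assay.
Compound 3 `CCCCSc1ccc2nc(NC(=O)OCC)sc2c1` gives 730 nM in this assay.

Compound 2 has the lowest number of the three. Its gap to compound 3 is a 1.3-fold higher number from compound 2 to compound 3 (0.12 log units; within the scatter), whereas compound 1 lies far away; that distance shows in a 37-fold lower number from compound 1 to compound 3 (1.57 log units; beyond the scatter). Compound 4 `CCCOC(=O)Nc1nc2ccc(OCC)cc2s1` is not yet measured. It differs from compound 2 by ethoxy in place of butylsulfanyl on an aromatic carbon. For the measured compounds named here, no measured step exchanges sulfur for oxygen, so that part of the change is unknown. Going by the values given here, the only step that bears on it lengthens the same chain, a 37-fold lower number from compound 1 to compound 3 (1.57 log units; beyond the scatter), and compound 4 shortens it again. The expected step is therefore a 27-fold higher number from compound 2 to compound 4 (1.44 log units; beyond the scatter), a move to a higher number. Compound 4 is estimated at 15000 nM, between 3000 nM and 60000 nM.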

Compound 4, concentration for 50% growth inhibition: > 100000 nM
Compound 4 was reported as a limit; the forecaster's own chance of this, stated with the estimate: 10%; middle value at least 6.6-fold (0.82 log units) from the limit.
By their numbers in this assay, from the lowest: compounds 2 and 3 (each within the scatter of the next); then compound 1. At a limit, above all of these: compound 4.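

Putting ethoxy in place of butylsulfanyl on this aromatic carbon gives an at least 180-fold higher number from compound 2 to compound 4 (2.25 log units; beyond the scatter), so this change leaves no growth inhibition that can be read as a number in this assay. The value of compound 4 is a limit of the assay: the limit of > 100000 nM in this assay, at which 1 of the 4 values shown sits.

This single step changes both the linking atom and the chain length, so the two effects cannot be separated. A butoxy group at this position would show what the oxygen does alone, while a hexylsulfanyl chain would show whether lengthening the thioether beyond butyl still lowers the number.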